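The source may hold more compounds than are shown below. What is called first, only, known or untested is meant among the compounds shown, and "the series" means these compounds.

Measured so far in an ADME assay on Huh-7 cells (Homo sapiens) for cytotoxicity, with a stated time of 72 h (on this read-out lower numbers stand for higher toxicity in this test and higher numbers for lower toxicity in this test), each value a limit of the assay and not a number:

- Compound 1 `Cc1cn([C@@H]2O[C@H](CO[Si](C)(C)C(C)(C)C)[C@@]3(OS(=O)(=O)C=C3N)[C@H]2O[Si](C)(C)C(C)(C)C)c(=O)n(C(=O)c2ccccc2)c1=O`: > 100000 nM
- Compound 2 `Cc1cn([C@@H]2O[C@H](CO[Si](C)(C)C(C)(C)C)[C@@]3(OS(=O)(=O)C=C3N)[C@H]2O[Si](C)(C)C(C)(C)C)c(=O)n(C(=O)CCCBr)c1=O`: > 100000 nM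
- Compound 3 `Cc1cn([C@@H]2O[C@H](CO[Si](C)(C)C(C)(C)C)[C@@]3(OS(=O)(=O)C=C3N)[C@H]2O[Si](C)(C)C(C)(C)C)c(=O)n(C(=O)C2CC2)c1=O`: > 100000 nM

These three compounds share one core and differ only in the group on a carbonyl carbon. Compound 3 gives > 100000 nM, which is only a limit. It therefore has no exact position relative to the other two compounds, and the whole series sits at one ceiling: the limit of > 100000 nM in this assay, at which 3 of the 3 values shown sit.

Compound 4 `Cc1cn([C@@H]2O[C@H](CO[Si](C)(C)C(C)(C)C)[C@@]3(OS(=O)(=O)C=C3N)[C@H]2O[Si](C)(C)C(C)(C)C)c(=O)n(C(=O)CCCC(N)=O)c1=O` is the next to be tested. It carries 3-carbamoylpropyl in place of cyclopropyl on a carbonyl carbon.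

Among the measured compounds shown here, three measured steps bear on this change: a step that the two limits leave unreadable from compound 1 to compound 2, a step that the two limits leave unreadable from compound 1 to compound 3 and a step that the two limits leave unreadable from compound 2 to compound 3. None of them has a readable size, so they cannot give a measured effect for the new group. They do show that phenyl, 3-bromopropyl and cyclopropyl at this place all left the compounds at the limit in this assay. A new group could still behave differently, so the range is kept wide on both sides.

The expected move, a number no higher from compound 3 to compound 4 (the limit leaves the size open), is no step in either direction beyond the usual scatter, and a further limit is the most likely report.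

The estimate for compound 4 is 100000 nM, with an expected range from 40000 nM to 200000 nM.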

Compound 4, half-maximal cytotoxic concentration: > 100000 nM
Compound 4 ended at the assay's limit (the forecaster's own chance of this, stated with the estimate: 80%); the middle value sits exactly at the limit.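

In this assay compound 4 gives > 100000 nM, which is a limit of the assay and not a number. No step among compound 1, compound 2, compound 3 and compound 4 can be read, and the series stays at one ceiling: the limit of > 100000 nM in this assay, at which 4 of the 4 values shown sit.

The compounds shown leave open whether, and by how much, these groups on a carbonyl carbon differ in half-maximal cytotoxic concentration.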